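Swapping Cyclopentyl for Cyanophenyl: Expected Effect on Toxicity

This account rests on a few compounds, and the source may have more. Where it says the series, first, only, none or still open, it means among the compounds named here.

Compound 1 `COc1ccc(-c2cnc(NC(=O)C3CCCC3)n2C)cc1` in a toxicity assay on THP-1 cells (Homo sapiens) for inhibition (on this read-out higher numbers stand for lower toxicity in this test and lower numbers for higher toxicity in this test), gives > 100000 nM, a limit of the assay.
Compound 2 `COc1ccc(-c2cnc(NC(=O)c3ccc(F)cc3)[nH]2)cc1` in this assay gives > 100000 nM, also a limit.

Compound 1 therefore stands at the limit of > 100000 nM in this assay, at which 2 of the 2 values shown sit, and nothing separates it from compound 2. Compound 3 `COc1ccc(-c2cnc(NC(=O)c3ccccc3C#N)n2C)cc1` differs from compound 1 by 2-cyanophenyl in place of cyclopentyl on a carbonyl carbon. Within the data shown here, no measured step shows what such a change does here, so its size is open. Compound 3 is expected to give about 100000 nM, between 40000 nM and 250000 nM, most likely again only a limit. The estimated step of a number no higher from compound 1 to compound 3 (the limit leaves the size open) is expected to stay within the scatter, in no particular direction.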

Compound 3, half-maximal cytotoxic concentration: > 100000 nM
Compound 3 was reported as a limit (the forecaster's own chance of this, stated with the estimate: 75%); the middle value lies on the limit itself.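

Compound 1 and compound 3 both sit at a limit of the assay, so no step between them can be read: the limit of > 100000 nM in this assay, at which 3 of the 3 values shown sit.

As far as these compounds go, whether 2-cyanophenyl in place of cyclopentyl on a carbonyl carbon changes the result in this assay at all, and in which direction, stays open.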